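This account rests on a few compounds, and the source may have more. Where it says the series, first, only, none or still open, it means among the compounds named here.

In a functional assay on PC-3 cells (Homo sapiens) (on this read-out higher numbers stand for weaker inhibition of growth and lower numbers for stronger inhibition of growth), compound 1 `O=S(=O)(/C=C/c1ccc(Cl)cc1)Cc1ccc(Nc2ncnc3ccccc23)cc1` gives 43000 nM and compound 2 `O=S(=O)(/C=C/c1ccc(Cl)cc1)Cc1ccc(Nc2ncnc3ccc(Br)cc23)cc1` gives 2000 nM, the lower of the two numbers and so the stronger inhibition of growth. The gap between them is a 22-fold lower number from compound 1 to compound 2 (1.33 log units; beyond the scatter), and it came from bromo in place of hydrogen on an aromatic carbon. Compound 3 `O=S(=O)(/C=C/c1ccc(F)cc1F)Cc1ccc(Nc2ncnc3ccc(Br)cc23)cc1` keeps that bromo and changes something else: 2,4-difluorophenyl in place of 4-chlorophenyl on a double-bonded chain carbon bound to a double-bonded chain carbon. That one measured step lies at a different place, so it gives no guide to size or direction here. No shift beyond the scatter is expected, and the estimated step is a 1.5-fold higher number from compound 2 to compound 3 (0.18 log units; within the scatter). For compound 3 the estimated value is 3000 nM, with a range from 800 nM to 11000 nM.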

Compound 3, concentration for 50% growth inhibition: 100000 nM
Compound 3: the middle estimate sits 33-fold (1.52 log units) below what was measured, outside the stated range (above it).
By their numbers in this assay, from the lowest: compound 2; then compound 1; then compound 3.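

Compound 2 and compound 3 show that the aromatic ring on this chain is not a neutral spot: in this assay, 2,4-difluorophenyl in place of 4-chlorophenyl gives a 50-fold higher number from compound 2 to compound 3 (1.70 log units; beyond the scatter), a large weakening of growth inhibition with the bromo kept in place. Until this step, only a change on the core had been seen to move the number. Nothing available explains this weakening.

Because the chlorine leaves as the two fluorines enter, the compounds shown leave open which part of the swap matters. Going by these compounds, how a plain phenyl or a methoxyphenyl would behave at this place also remains open.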